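From Nitrile to Primary Amide on the Indole

A few compounds are considered here, and "the series" means these few. Any claim that something is new, unique, unknown or untested is made for them only; others in the source may bear on it.

Of the compounds shown here, two sharing a core have been measured so far. Compound 1 `COc1ccc(NC(=O)N2CCC(c3c[nH]c4cc(F)ccc34)CC2)cc1N1CCN(C)CC1` gives 80 nM in an assay on frontal cortex for binding affinity to 5-hydroxytryptamine receptor 1B (Rattus norvegicus), read by radioligand binding; on this read-out lower numbers stand for stronger inhibition and higher numbers for weaker inhibition. For the measured compounds named here, compound 2 `COc1ccc(NC(=O)N2CCC(c3c[nH]c4ccc(C#N)cc34)CC2)cc1N1CCN(C)CC1` gives 267 nM in this assay, which is the higher of the two numbers, and the single step between them, a 3.3-fold higher number from compound 1 to compound 2 (0.52 log units; beyond the scatter), lies beyond the scatter. Compound 3 `COc1ccc(NC(=O)N2CCC(c3c[nH]c4ccc(C(N)=O)cc34)CC2)cc1N1CCN(C)CC1` has not yet been measured. It differs from compound 2 in one place: carbamoyl in place of cyano on an aromatic carbon. Going by the values given here, no measured step bears directly on this exchange; the only step in hand, from compound 1 to compound 2, concerns a different substituent at a different position and says nothing about a nitrile becoming an amide. With nothing to anchor the direction, compound 3 is expected to land near compound 2, with the step from compound 2 to compound 3 estimated as a 1.5-fold lower number from compound 2 to compound 3 (0.17 log units; within the scatter), most likely not beyond the scatter. On that basis compound 3 is estimated at 180 nM in this assay, with a plausible range from 45 nM to 700 nM.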

Compound 3, half-maximal inhibitory concentration: 113 nM
Beside the measured number, compound 3's estimate is 1.6-fold (0.20 log units) above it; measured number inside the range.
By their numbers in this assay, from the lowest: compounds 1 and 3 (each within the scatter of the next); then compound 2.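

Exchanging cyano for carbamoyl on this aromatic carbon lowers the number in this assay (a 2.4-fold lower number from compound 2 to compound 3 (0.37 log units; beyond the scatter)), which shows that the read-out responds to the group held at this place on the indole. The comparison with the fluoro compound runs a 1.4-fold higher number from compound 1 to compound 3 (0.15 log units; within the scatter), so 5-carbamoyl-1H-indol-3-yl and 6-fluoro-1H-indol-3-yl cannot be told apart here, even though the two groups also sit in different places, and the higher number of compound 2 is therefore not shared by every substituted indole in this set. Nothing available here explains why carbamoyl and cyano read differently at this place.

Still open, from the compounds shown here alone, is whether the lower number tracks the carbonyl or the amide hydrogen, which a methyl amide, a dimethyl amide or a carboxylic acid at this place could begin to separate. Also open, going by these compounds, is how carbamoyl would read in the place that fluoro holds in compound 1, and whether an aminomethyl group or a longer chain would be tolerated on this aromatic carbon.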